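Swapping a nitrile chain for an amine on the core

This account rests on a few compounds, and the source may have more. Where it says the series, first, only, none or still open, it means among the compounds named here.

Compound 3 `N#CCCc1cnc(-c2nn(Cc3ccccc3F)c3ncccc23)nc1N` sits second highest among the three numbers in a functional assay (aorta) with Oryctolagus cuniculus as the target; a lower number here means a stronger inhibitor, a higher number a weaker inhibitor: it gives 412000 nM, while compound 1 `Cc1cnc(-c2nn(Cc3ccccc3F)c3ncccc23)nc1N` gives 675000 nM and compound 2 `CC(C)c1cnc(-c2nn(Cc3ccccc3F)c3ncccc23)nc1N` gives 207000 nM. The change now followed yields compound 4 `NCc1cnc(-c2nn(Cc3ccccc3F)c3ncccc23)nc1N`, with amino in place of cyanomethyl on a saturated chain carbon bound to an aromatic carbon. The step that touches the same saturated chain carbon, a 1.6-fold lower number from compound 1 to compound 3 (0.21 log units; within the scatter), stayed within the scatter, so adding or removing a cyanomethyl group there barely moved the number. Among the measured compounds shown here, nothing measured so far speaks to an amino group at that place. Expected, then, is a 1.2-fold higher number from compound 3 to compound 4 (0.08 log units; within the scatter), a step not beyond the scatter. Compound 4 is therefore estimated at 500000 nM, with a range from 150000 nM to 1500000 nM.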

Compound 4, half-maximal inhibitory concentration: 1400000 nM
Beside the measured number, compound 4's estimate is 2.8-fold (0.45 log units) below it; the range from low to high includes it.
By their numbers in this assay, from the lowest: compounds 2, 3 and 1 (each within the scatter of the next, the first and the last beyond it); then compound 4.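

In this assay, amino on this saturated chain carbon, unlike cyanomethyl, moves the number beyond the scatter, with a 2.1-fold higher number from compound 1 to compound 4 (0.32 log units; beyond the scatter) and a 3.4-fold higher number from compound 3 to compound 4 (0.53 log units; beyond the scatter) on record. Aminomethyl in place of isopropyl gives the largest step seen at this place, a 6.8-fold higher number from compound 2 to compound 4 (0.83 log units; beyond the scatter), which leaves compound 4 as the weakest inhibitor of the four. No measured evidence accounts for this result. Still open, going by these compounds, is whether a longer chain ending in an amine, or a hydroxymethyl group, would behave like aminomethyl or like 2-cyanoethyl.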